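The compounds below may be only part of what the source reports. "The series", "measured", "known", "first", "only" and "open" are said of these compounds alone.

Measured so far in a functional assay on FM3A cells (Mus musculus) for antiproliferative activity, with a stated time of 48 h; on this read-out higher numbers stand for weaker inhibition and lower numbers for stronger inhibition:
compound 1, `C=C(Br)C(=O)Nc1ccc(/C=C/C(=O)c2ccccc2)cc1`: 3900 nM
compound 2, `C=C(Br)C(=O)Nc1ccc(/C=C/C(=O)c2ccc(OC)cc2)cc1`: 1200 nM
compound 3, `Nc1ccc(C(=O)/C=C/c2ccccc2)cc1`: 34000 nM

Compound 2 differs from compound 1 by methoxy in place of hydrogen on an aromatic carbon, and this gave a 3.3-fold lower number from compound 1 to compound 2 (0.51 log units; beyond the scatter). Compound 3 gives the highest number of the three. How the core of compound 3 differs from the core of compound 1 is not broken down here.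

Not yet measured is compound 4, `COc1ccccc1/C=C/C(=O)c1ccc(N)cc1`, which differs from compound 3 by methoxy in place of hydrogen on an aromatic carbon. The change is the same kind of change as from compound 1 to compound 2, not the same: in compound 2 the methoxy sits para to a large group, in compound 4 ortho to a large group, and the cores differ.

Compound 4 is expected to give a 2.0-fold lower number from compound 3 to compound 4 (0.30 log units; within the scatter). This rests on the step of a 3.3-fold lower number from compound 1 to compound 2 (0.51 log units; beyond the scatter), discounted since the place and core are not the same. For compound 4 the estimate is 17000 nM, between 6000 nM and 50000 nM.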

Compound 4, half-maximal inhibitory concentration: 25000 nM
Beside the measured number, compound 4's estimate is 1.5-fold (0.17 log units) below it; low and high end bracket the measured number.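

In this assay, methoxy in place of hydrogen on an aromatic carbon gives a 1.4-fold lower number from compound 3 to compound 4 (0.13 log units; within the scatter), so on this core the change cannot be told from the scatter. The earlier step and this one do not differ beyond what two such steps allow: the same change on two cores in this assay, a 3.3-fold lower number (0.51 log units; beyond the scatter) from compound 1 to compound 2 and a 1.4-fold lower number (0.13 log units; within the scatter) from compound 3 to compound 4, 2.4-fold (0.38 log units) apart, within the scatter of two such steps. That agrees with the change carrying over between the two cores but does not demonstrate it, as one step lies within the scatter, and the two pairs differ in both the core and the place of the methoxy.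

Left open is what methoxy ortho to a large group would do on the core of compound 1. Also open, as far as these compounds go, is whether hydroxy, fluorine or a carboxylic acid at that place would give a step beyond the scatter.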